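The source may report more compounds than this note shows. Statements on the series, on what has been measured and on what is new or still open speak of the compounds shown alone.

Compound 1, `O=C(Nc1ccc(Oc2ccnc3[nH]ccc23)c(F)c1)c1ccc(-c2ccccc2)cn1`, and compound 2, `Cc1ccc(-c2ccc(C(=O)Nc3ccc(Oc4ccnc5[nH]ccc45)c(F)c3)nc2)cc1`, share a core and differ only at a single aromatic carbon. In a functional assay on A549 cells (Homo sapiens) for cytotoxicity, read by MTT assay, with a stated time of 72 h (on this read-out lower numbers stand for stronger inhibition and higher numbers for weaker inhibition), compound 1 gives 1250 nM, and compound 2 gives 2300 nM. Among the compounds with values here, the one measured step, a 1.8-fold higher number from compound 1 to compound 2 (0.26 log units; within the scatter), places compound 2 at the higher of the two numbers seen so far, though the gap to compound 1 is within the scatter, so no order between the two can be claimed.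

Compound 3, `COc1ccc(-c2ccc(C(=O)Nc3ccc(Oc4ccnc5[nH]ccc45)c(F)c3)nc2)cc1`, follows from compound 2 by a change at the same part of the molecule: methoxy in place of methyl on an aromatic carbon. Within the data shown here, no measured step bears on a methoxy group directly; the only step at hand, from hydrogen to methyl, stayed within the scatter. With nothing else to go on, the expectation for compound 3 is a step of about a 1.2-fold lower number from compound 2 to compound 3 (0.06 log units; within the scatter) in this assay, which is to say no change beyond the scatter in either direction. Compound 3 is therefore estimated at 2000 nM, with a range from 800 nM to 5000 nM.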

Compound 3, half-maximal inhibitory concentration: 2240 nM
Beside the measured number, compound 3's estimate is 1.1-fold (0.05 log units) below it; the range from low to high includes it.
By their numbers in this assay, from the lowest: compounds 1, 3 and 2 (each within the scatter of the next).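

In this assay the change from 4-methylphenyl to 4-methoxyphenyl comes with a 1.0-fold lower number from compound 2 to compound 3 (0.01 log units; within the scatter) and the change from hydrogen to methoxy comes with a 1.8-fold higher number from compound 1 to compound 3 (0.25 log units; within the scatter) on the same aromatic carbon, para to a large group. This carbon has now carried hydrogen, methyl and methoxy with no step beyond the scatter, so the flat result seen for methyl alone extends to a second, larger group, and the compounds cannot be put in any order. Methoxy also brings an oxygen and a hydrogen-bond acceptor that methyl lacks, yet this difference in the counted atoms shows no separate trace in the numbers, and no evidence at hand bears on this result.

The compounds shown leave open whether any group at this carbon can move the number beyond the scatter, for instance an amine, a carboxylic acid or a chlorine atom. They also leave open whether a longer chain, such as ethoxy or butoxy in place of methoxy, would stay as close to compound 1 as methyl and methoxy do.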